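From Furan-2-yl to Thiophen-3-yl on Compound 3

The source may hold more compounds than are shown below. What is called first, only, known or untested is meant among the compounds shown, and "the series" means these compounds.

Three related compounds have been tested so far in a functional assay on A549 cells (Homo sapiens), read by MTT assay, with a stated time of 72 h; a lower number here means a stronger inhibitor, a higher number a weaker inhibitor. Within the data shown here, compound 1 (`COc1ncnc2c1c(-c1cc3ccccc3o1)cn2[C@@H]1O[C@H](CO)[C@@H](O)[C@H]1O`) gives 17700 nM, the only exact number among them. Compound 2 (`CSc1ncnc2c1c(-c1cccs1)cn2[C@@H]1O[C@H](CO)[C@@H](O)[C@H]1O`) reads > 20000 nM, which is a limit of the assay and not a number. Compound 3 (`Nc1nc(N)c2c(-c3ccco3)cn([C@@H]3O[C@H](CO)[C@@H](O)[C@H]3O)c2n1`) reads > 20000 nM, which is also a limit and not a number. That places compound 3 at the limit of > 20000 nM in this assay, at which 2 of the 3 values shown sit.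

Compound 4 (`Nc1nc(N)c2c(-c3ccsc3)cn([C@@H]3O[C@H](CO)[C@@H](O)[C@H]3O)c2n1`) has not been measured yet. It keeps the core of compound 3 and changes one group, with thiophen-3-yl in place of furan-2-yl on an aromatic carbon. Among the measured compounds shown here, no measured pair in this small set shows what such a swap does, so the forecast has little to stand on.

The expected outcome in this assay is no step beyond the scatter, and the estimated move is an at least 1.1-fold lower number from compound 3 to compound 4 (0.04 log units; that floor lies within the scatter). This expectation starts from compound 3, whose reading of > 20000 nM is a limit, so any true change may stay hidden. For compound 4 the estimate is 18000 nM, with an expected range from 6000 nM to 25000 nM.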

Compound 4, half-maximal inhibitory concentration: > 100000 nM
Compound 4 gave a limit, no number (the forecaster's own chance of this, stated with the estimate: 65%); at least 5.5-fold (0.74 log units) between middle value and limit.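

In this assay compound 3 reads > 20000 nM, a limit of the assay and not a number. Among these compounds, compound 4 reads > 100000 nM, also a limit, so no step from compound 3 to compound 4 can be read. The compounds shown leave open how strongly either one truly inhibits, and whether thiophen-3-yl in place of furan-2-yl changes that at all.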